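Amide-nitrogen ring swap in the shared core

The source may hold more compounds than are shown below. What is called first, only, known or untested is meant among the compounds shown, and "the series" means these compounds.

Compound 2 `COc1ccc(C(=O)NC2(C)C=C(C)ON2)cc1OC1CCCC1` carries, on the amide-type nitrogen of the shared core, a five-membered non-aromatic ring with two hetero atoms; in an assay on isolated protein for inhibition of phosphodiesterase 4A (Sus scrofa) (on this read-out lower numbers stand for stronger inhibition and higher numbers for weaker inhibition), compound 2 gives 450 nM. This is the higher of the two numbers recorded so far. The nearest neighbour is compound 1 `COc1ccc(C(=O)Nc2ccccc2Br)cc1OC1CCCC1`, which in this assay gives 130 nM; the step between them is a 3.5-fold higher number from compound 1 to compound 2 (0.54 log units; beyond the scatter).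

Compound 3 `COc1ccc(C(=O)Nc2c(C)nsc2C)cc1OC1CCCC1` is the next member. The change is a group of 7 heavy atoms (5 carbon, 1 nitrogen, 1 sulfur; one five-membered aromatic ring with 2 hetero atoms) in place of a group of 7 heavy atoms (5 carbon, 1 nitrogen, 1 oxygen; one five-membered non-aromatic ring with 2 hetero atoms), on an amide-type nitrogen. For the measured compounds named here, no measured pair shows this exact exchange. Going by the values given here, the single step in hand, a 3.5-fold higher number from compound 1 to compound 2 (0.54 log units; beyond the scatter), bears on it only at one remove: there a six-membered aromatic ring of carbon only gave way to the five-membered non-aromatic ring and the number rose. Compound 3 returns to an aromatic ring, now five-membered with two hetero atoms, so a modest move back toward the number of compound 1 is expected, with wide uncertainty because the new ring matches neither measured neighbour. For compound 3 the expected step from compound 2 is a 2.0-fold lower number from compound 2 to compound 3 (0.31 log units; beyond the scatter). Compound 3 is estimated at 220 nM, within 80 nM to 650 nM.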

Compound 3, half-maximal inhibitory concentration: 500 nM
For compound 3 the middle estimate is 2.3-fold (0.36 log units) below the measured one, and the stated range covers the measured number.
By their numbers in this assay, from the lowest: compound 1; then compounds 2 and 3 (each within the scatter of the next).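

At the amide-type nitrogen of the shared core, 3,5-dimethyl-1,2-thiazol-4-yl in place of the five-membered non-aromatic ring gives (a 1.1-fold higher number from compound 2 to compound 3 (0.05 log units; within the scatter)) in this assay, so the presence of an aromatic ring at this position does not by itself separate compound 2 and compound 3. Measured against the 2-bromophenyl group of compound 1, both five-membered rings stand beyond the scatter, the non-aromatic ring with (a 3.5-fold higher number from compound 1 to compound 2 (0.54 log units; beyond the scatter)) and 3,5-dimethyl-1,2-thiazol-4-yl with (a 3.8-fold higher number from compound 1 to compound 3 (0.59 log units; beyond the scatter)), which places the difference among these three compounds between 2-bromophenyl and the two five-membered rings rather than between aromatic and non-aromatic rings. No supporting measurement is available to account for these numbers.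

Going by these compounds, whether the lower number of compound 1 goes with its six-membered aromatic ring or with its bromine remains open, and an unsubstituted phenyl or a 2-chlorophenyl group on the same nitrogen would separate the two. On these data alone, the contribution of the methyl groups on the sulfur-containing ring is also open, a question that the unsubstituted 1,2-thiazol-4-yl group would address directly.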